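Adding a Methoxy Group to a Pyrazole Chalcone

The source may report more compounds than this note shows. Statements on the series, on what has been measured and on what is new or still open speak of the compounds shown alone.

Measured compounds:
compound 1 `COc1cc(-c2cc(/C=C/C(=O)c3ccc(N)cc3)[nH]n2)cc(OC)c1OC`, 65800 nM
compound 2 `COc1ccc(C(=O)/C=C/c2cc(-c3cc(OC)c(OC)c(OC)c3)n[nH]2)cc1OC`, 15700 nM
compound 3 `COc1ccc(-c2cc(/C=C/C(=O)c3ccc(N)cc3)[nH]n2)cc1OC`, > 100000 nM

All three were tested in a functional assay on NCI/ADR-RES cells (Homo sapiens) for inhibition, read by sulforhodamine B assay, with a stated time of 48 h; a lower number here means a stronger inhibitor of growth, a higher number a weaker inhibitor of growth. Compound 3 gives only a limit of the assay, > 100000 nM, and no number; the limit of > 100000 nM in this assay, at which 1 of the 3 values shown sits, marks that floor. Compound 1 differs from compound 3 by methoxy in place of hydrogen on an aromatic carbon, and the step is an at least 1.5-fold lower number from compound 3 to compound 1 (0.18 log units; that floor lies within the scatter). Compound 1 and compound 2 differ in a different way, 3,4-dimethoxyphenyl in place of 4-aminophenyl on a carbonyl carbon, and that gives a 4.2-fold lower number from compound 1 to compound 2 (0.62 log units; beyond the scatter), so compound 2 has the lowest number of the two that were measured as numbers. The difference between the core of compound 2 and the core of compound 3 is not broken down here.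

Compound 4 `COc1cc(C(=O)/C=C/c2cc(-c3cc(OC)c(OC)c(OC)c3)n[nH]2)cc(OC)c1OC` is not yet measured. For the measured compounds named here, it differs from compound 2 by methoxy in place of hydrogen on an aromatic carbon, which is the same change, in the same kind of surroundings, as the one from compound 3 to compound 1. Because that earlier step was an at least 1.5-fold lower number from compound 3 to compound 1 (0.18 log units; that floor lies within the scatter), a modest move in the same direction is expected from compound 2 to compound 4, roughly a 2.0-fold lower number from compound 2 to compound 4 (0.29 log units; within the scatter), though it rests on a single step whose true size is only partly known. For compound 4 the expected value in this assay is 8000 nM, with a likely range from 3000 nM to 30000 nM.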

Compound 4, concentration for total growth inhibition: 21400 nM
Beside the measured number, compound 4's estimate is 2.7-fold (0.43 log units) below it; the measured number falls inside the stated range.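

In this assay, methoxy in place of hydrogen on an aromatic carbon gives a 1.4-fold higher number from compound 2 to compound 4 (0.13 log units; within the scatter), so on this core the added group produces no change that can be told apart from the ordinary spread of repeated measurements. Compound 3 carries only a limit of the assay, > 100000 nM, which means the earlier step on the other core has a floor and no exact size. Set side by side, the two steps neither show that the change carries over from one core to the other nor show that it fails to, and the comparison stands as follows: the same change on two cores in this assay, an at least 1.5-fold lower number (0.18 log units; that floor lies within the scatter) from compound 3 to compound 1 and a 1.4-fold higher number (0.13 log units; within the scatter) from compound 2 to compound 4; the limit leaves it open whether they differ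

The compounds shown leave open whether a different group in place of this methoxy group, such as a hydroxyl, an ethoxy group or a carboxylic acid, would move the number in this assay beyond the scatter. They also leave open how large the step from hydrogen to methoxy really is on the core of compound 1, and so whether the two cores truly respond to this change in different ways.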